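Side-chain homologation in an antiproliferative series

The source may report more compounds than this note shows. Statements on the series, on what has been measured and on what is new or still open speak of the compounds shown alone.

Measured compounds in a functional assay on HCT-116 cells (Homo sapiens) for antiproliferative activity, read by MTT assay, with a stated time of 48 h; a higher number here means a weaker inhibitor, a lower number a stronger inhibitor:
compound 1, `CCCCC(CCO)n1cnc2cncnc21`, gives > 50000 nM; this is a limit of the assay.
compound 3, `CCCCCC(CCO)n1cnc2cncnc21`, gives > 50000 nM; this is a limit of the assay too.
compound 2, `CCCCCC(CCO)n1cnc2c(Cl)nc(F)nc21`, gives 8660 nM, the only number among the three.

Compound 3 differs from compound 1 by methyl in place of hydrogen on a saturated chain carbon, five bonds along the chain from an aromatic nitrogen. The step that the two limits leave unreadable from compound 1 to compound 3 cannot be read, since both values sit at a limit; see (the limit of > 50000 nM in this assay, at which 2 of the 3 values shown sit). Compound 2 and compound 1 have different cores; that difference is not broken down here.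

Compound 4, `CCCCCCC(CCO)n1cnc2c(Cl)nc(F)nc21`, is not yet measured; it differs from compound 2 by methyl in place of hydrogen on a saturated chain carbon, six bonds along the chain from an aromatic nitrogen. This is the same kind of change as from compound 1 to compound 3, but the place is not identical: five bonds along the chain from an aromatic nitrogen there, six bonds along the chain from an aromatic nitrogen here. The earlier step gives no usable size, so the expectation for compound 4 rests on compound 2 alone, whose value 8660 nM serves as the anchor. The step of a 1.1-fold lower number from compound 2 to compound 4 (0.03 log units; within the scatter) is expected to stay within the usual scatter. Compound 4 is thus estimated at 8000 nM, between 3500 nM and 18000 nM.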

Compound 4, half-maximal inhibitory concentration: 9960 nM
Estimate against measurement, compound 4: 1.2-fold (0.10 log units) below, within the range that was stated.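

In this assay, the added methyl on the core of compound 2 gives a 1.2-fold higher number from compound 2 to compound 4 (0.06 log units; within the scatter), so on this core the step is a readable one that stays inside the usual scatter. The same kind of change on the core of compound 1 cannot be read, since compound 1 and compound 3 both sit at a limit of the assay and so provide no size to set against the new step: the limit of > 50000 nM in this assay, at which 2 of the 4 values shown sit. The notes therefore hold one readable step on one core, at a place six bonds along the chain from an aromatic nitrogen, and they do not show whether the change carries from one core to the other.

Open, on these data alone, is how a longer chain than that of compound 4 would read on the core of compound 2, since a single added methyl says nothing about the further reach of the series. Also open, as far as these compounds go, is how an amine in place of the hydroxyl would read on this core.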